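Taking the fluoro group off compound 3

This account rests on a few compounds, and the source may have more. Where it says the series, first, only, none or still open, it means among the compounds named here.

Compound 1 `COc1ccc(CSc2nnc([C@@H](C)c3ccc4cc(OC)ccc4c3)n2-c2ccc(Cl)cc2)cc1` gives <= 400000 nM as a limit of the assay
Compound 2 `COc1cccc(CSc2nnc([C@@H](C)c3ccc4cc(OC)ccc4c3)n2-c2ccc(Cl)cc2)c1` gives 162000 nM as a measured value
Compound 3 `COc1ccc2cc([C@H](C)c3nnc(SCc4ccc(F)cc4)n3-c3ccc(Cl)cc3)ccc2c1` gives 33900 nM as a measured value

These results come from a functional assay on LNCaP cells (Homo sapiens) for cytotoxicity, read by MTT assay (on this read-out lower numbers stand for stronger inhibition and higher numbers for weaker inhibition), and show compound 3 with the lower of the two true numbers. For the measured compounds named here, its only readable comparison is a 4.8-fold lower number from compound 2 to compound 3 (0.68 log units; beyond the scatter) and this lies beyond the scatter.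

Compound 4 `COc1ccc2cc([C@H](C)c3nnc(SCc4ccccc4)n3-c3ccc(Cl)cc3)ccc2c1` has hydrogen in place of fluoro on an aromatic carbon, para to a large group, as counted in hydrogen in place of fluoro on an aromatic carbon and turning 4-fluorobenzyl into benzyl. Going by the values given here, no measured step makes this exact change. The closest guide is compound 3 with a 4.8-fold lower number from compound 2 to compound 3 (0.68 log units; beyond the scatter) as a modest step at the same group, though it replaces a different substituent. Among the compounds with values here, compound 1 adds no size through a step that the limit leaves unreadable from compound 1 to compound 3 as its step. The expected change is small and upward, given as a 1.5-fold higher number from compound 3 to compound 4 (0.17 log units; within the scatter) and estimated to stay within the scatter. The estimated value for compound 4 is 50000 nM with an expected range from 15000 nM to 170000 nM in this assay.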

Compound 4, half-maximal inhibitory concentration: 50400 nM
For compound 4 the middle estimate is 1.0-fold (0.00 log units) below the measured one; the range from low to high includes it.
By their numbers in this assay, from the lowest: compounds 3 and 4 (each within the scatter of the next); then compound 2.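

In this assay, hydrogen in place of fluoro on the aromatic carbon para to a large group gives a 1.5-fold higher number from compound 3 to compound 4 (0.17 log units; within the scatter), so this assay does not separate 4-fluorobenzyl from benzyl at this position. Hydrogen in place of methoxy gives a 3.2-fold lower number from compound 2 to compound 4 (0.51 log units; beyond the scatter), which shows that the lower number seen earlier with compound 3 does not need the fluoro and is kept with an unsubstituted phenyl. Compound 1 has a limit, so its step to compound 4 cannot be read, and neither can its other steps: the limit of <= 400000 nM in this assay, at which 1 of the 4 values shown sits.

The effect of the 4-methoxyphenyl group therefore remains unresolved. From the compounds shown here alone, it also remains open how an amine, a carboxylic acid or a trifluoromethyl group on this same aromatic carbon would compare with hydrogen and fluoro.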